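From Nitro to Amino on a Nucleoside Carboxamide

The source may report more compounds than this note shows. Statements on the series, on what has been measured and on what is new or still open speak of the compounds shown alone.

Compound 1 `NC(=O)c1ccn(C2O[C@H](CO)[C@@H](O)[C@H]2O)n1` gives 1030 uM in a functional assay on Raji cells (Homo sapiens); a higher number here means a weaker inhibitor, a lower number a stronger inhibitor. Compound 2 `NC(=O)c1nn(C2O[C@H](CO)[C@@H](O)[C@H]2O)cc1[N+](=O)[O-]` differs from it by a nitro in place of hydrogen on an aromatic carbon. In this assay compound 2 reaches only a limit, > 1730 uM. The step of an at least 1.6-fold higher number from compound 1 to compound 2 (0.22 log units; that floor lies within the scatter) therefore rests on the limit of > 1730 uM in this assay, at which 1 of the 2 values shown sits, and cannot be sized further. Compound 3 `NC(=O)c1nn(C2O[C@H](CO)[C@@H](O)[C@H]2O)cc1N` differs from compound 2 by amino in place of nitro on an aromatic carbon. Among the measured compounds shown here, no measured step covers an amino group here, so the expected change an at least 1.3-fold lower number from compound 2 to compound 3 (0.12 log units; that floor lies within the scatter) leans on compound 1 and its hydrogen giving 1030 uM. Compound 3 is expected to give about 1300 uM, between 450 uM and 3500 uM.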

Compound 3, concentration for 50% inhibition: 1280 uM
Beside the measured number, compound 3's estimate is 1.0-fold (0.01 log units) above it; low and high end bracket the measured number.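

Amino in place of hydrogen gives the first fully sized step at this position in this assay: a 1.2-fold higher number from compound 1 to compound 3 (0.09 log units; within the scatter), so the two groups cannot be told apart here. Amino in place of nitro gives an at least 1.3-fold lower number from compound 2 to compound 3 (0.13 log units; that floor lies within the scatter), which is only a floor. Compound 2 stands at a limit, not a number: the limit of > 1730 uM in this assay, at which 1 of the 3 values shown sits.

Going by these compounds, how far nitro truly lies from amino stays open. So does whether a different group on this aromatic carbon, such as a carboxylic acid or a methoxy group, would shift the number beyond the scatter.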